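This account rests on a few compounds, and the source may have more. Where it says the series, first, only, none or still open, it means among the compounds named here.

Compound 1 `CS(=O)(=O)c1ccc(-n2ccc3cnc(Nc4cnn(CCCCCCC(=O)NO)c4)nc32)cc1`: 5.9 nM in an assay on isolated protein for inhibition of protein deacetylase HDAC6 (Homo sapiens), with a stated time of 60 min; a lower number here means a stronger inhibitor, a higher number a weaker inhibitor
Compound 2 `CS(=O)(=O)c1ccc(-n2ccc3cnc(Nc4cnn(CCCCCC(=O)NO)c4)nc32)cc1`: 10.8 nM in this assay

Going by the values given here, the two numbers lie within the scatter of each other, as the one measured step shows: a 1.8-fold higher number from compound 1 to compound 2 (0.26 log units; within the scatter). Compound 2 is therefore not set apart from compound 1. Compound 3 `O=C(CCCCCn1cc(Nc2ncc3ccn(Cc4cccc(F)c4)c3n2)cn1)NO` differs from compound 2 by 3-fluorobenzyl in place of 4-(methylsulfonyl)phenyl on an aromatic nitrogen. Among the compounds with values here, the measured step alters the chain, not the group on the aromatic nitrogen, so no measured step bears on this change and its direction cannot be read from the data. Compound 3 is expected to give 15 nM in this assay, within 4 nM to 60 nM. The step this estimate implies is a 1.4-fold higher number from compound 2 to compound 3 (0.14 log units; within the scatter).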

Compound 3, half-maximal inhibitory concentration: 13.7 nM
Estimate against measurement, compound 3: 1.1-fold (0.04 log units) above; low and high end bracket the measured number.
By their numbers in this assay, from the lowest: compounds 1, 2 and 3 (each within the scatter of the next, the first and the last beyond it).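

On the aromatic nitrogen, 3-fluorobenzyl stands in place of 4-(methylsulfonyl)phenyl with little effect on the number in this assay (a 1.3-fold higher number from compound 2 to compound 3 (0.10 log units; within the scatter)), so the two groups are not set apart here. This holds even though the group that leaves has 2 hydrogen-bond acceptors and the group that enters has 0. No measurement shown here accounts for this result.

From the compounds shown here alone, whether 3-fluorobenzyl reads the same on the longer chain of compound 1 remains open. So does the effect of a benzyl carrying an amine or a carboxylic acid at this position.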